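Swapping Methyl for Fluoro: Weighing the Expected Cytotoxicity

The source may report more compounds than this note shows. Statements on the series, on what has been measured and on what is new or still open speak of the compounds shown alone.

Compound 1 `C/C(=C\c1cc(-c2cccnc2)co1)C(N)=O` is the reference point: in a functional assay on A549 cells (Homo sapiens) for cytotoxicity, read by CCK-8 assay, with a stated time of 24 h (a lower number here means a stronger inhibitor, a higher number a weaker inhibitor), compound 1 gives 6620 nM. Compound 2 `C/C(=C\c1cc(-c2ccc(C)nc2)co1)C(N)=O` carries a methyl on the six-membered aromatic ring with one nitrogen. In this assay compound 2 reaches only the limit of > 50000 nM, so no exact number is known for it. The step of an at least 7.5-fold higher number from compound 1 to compound 2 (0.87 log units; beyond the scatter) is thus bounded by that limit (the limit of > 50000 nM in this assay, at which 1 of the 2 values shown sits). Compound 3 `C/C(=C\c1cc(-c2ccc(F)nc2)co1)C(N)=O` differs from compound 2 by fluoro in place of methyl on an aromatic carbon. With only the methyl step as a guide, compound 3 is expected to sit below the limit, with an estimated value of 20000 nM, spanning 7000 nM to 60000 nM. That expected change corresponds to the step of an at least 2.5-fold lower number from compound 2 to compound 3 (0.39 log units; beyond the scatter).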

Compound 3, half-maximal inhibitory concentration: > 50000 nM
Compound 3: only a limit was reported; the forecaster's own chance of this, stated with the estimate: 35%; at least 2.5-fold (0.39 log units) between middle value and limit.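

In this assay, fluoro in place of hydrogen on the aromatic carbon next to the ring nitrogen gives an at least 7.5-fold higher number from compound 1 to compound 3 (0.87 log units; beyond the scatter). Two different groups at this position, methyl and fluoro, now both give a weaker result than the unsubstituted compound 1. Which of the two is weaker cannot be read, because the values of compound 2 and compound 3 are both limits of the assay, not numbers: the limit of > 50000 nM in this assay, at which 2 of the 3 values shown sit.

The compounds shown leave open whether every group here has this effect. An amine or a longer chain such as propyl at this carbon could still behave differently.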